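The compounds below may be only part of what the source reports. "The series", "measured", "known", "first", "only" and "open" are said of these compounds alone.

Measured compounds:
- compound 1, `CC1CCN(c2c(S(=O)(=O)c3ccc(F)cc3)cnc3ccc(F)cc23)CC1`, 87%
- compound 2, `Cc1ccc(S(=O)(=O)c2cnc3ccc(F)cc3c2N2CCC(C)CC2)cc1F`, 86%

Both compounds were tested in an assay on isolated protein for displacement of a labelled ligand from metabotropic glutamate receptor 5 (Homo sapiens), with a stated time of 60 min, tested at 1 uM; a higher number here means more inhibition at the concentration tested (going by the name of the read-out), a lower number less inhibition. Among the measured compounds shown here, compound 1 gives 87% and compound 2 gives 86%; the single measured step, a number 1 percentage points lower from compound 1 to compound 2 (within the scatter), shows that exchanging 4-fluorophenyl for 3-fluoro-4-methylphenyl on the sulfonyl sulfur left the read-out essentially unchanged. Compound 2 therefore stands level with compound 1 on the numbers shown, the two within the scatter of each other.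

Compound 3, `Cc1ccc(S(=O)(=O)c2cnc3ccc(F)cc3c2N2CCC(C)CC2)cc1Cl`, is not yet measured. It differs from compound 2 only as follows: chloro in place of fluoro on an aromatic carbon. For the measured compounds named here, no measured step exchanges one halogen for another on this aromatic ring, so the only guide is that the one change made so far at this ring, a number 1 percentage points lower from compound 1 to compound 2 (within the scatter), stayed within the scatter. On that basis the step of a number 2 percentage points lower from compound 2 to compound 3 (within the scatter) is expected to be small, with no clear direction. Compound 3 is estimated at 84%, with a range from 70% to 95%.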

Compound 3, a percentage reported as inhibition, at one concentration (the size of the read-out at that concentration, not a potency): 91%
Compound 3: the middle estimate sits 7 percentage points below what was measured; the range from low to high includes it.
By their numbers in this assay, from the lowest: compounds 2, 1 and 3 (each within the scatter of the next).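

Among the compounds shown here, the first exchange of one halogen for another on this ring, chloro in place of fluoro on the aromatic carbon ortho to a methyl group, gives a number 5 percentage points higher from compound 2 to compound 3 (within the scatter) in this assay, so this position accepts either halogen without a change that can be told from the scatter. Seen from the simpler aryl group, 3-chloro-4-methylphenyl in place of 4-fluorophenyl on the sulfonyl sulfur gives a number 4 percentage points higher from compound 1 to compound 3 (within the scatter), so this larger change of the aryl group also stays within the scatter. No supporting evidence is available to explain these results.

Going by these compounds, whether a methoxy group, a nitrile or an amine at this same ring carbon would move the number beyond the scatter remains open. A percentage at one concentration also leaves open how the potencies of these compounds compare.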